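The compounds below may be only part of what the source reports. "The series", "measured", "known", "first", "only" and "open" are said of these compounds alone.

Measured in an ADME assay on RAW264.7 cells (Mus musculus) for cytotoxicity, read by MTT assay; a higher number here means a weaker inhibitor, a lower number a stronger inhibitor:
- Compound 1 `CCCCCCCCCCOc1cccc(O)c1C(=O)/C=C/c1ccc(O)cc1`: > 30000 nM
- Compound 2 `CCCCCCCCCCCCCCOc1cccc(O)c1C(=O)/C=C/c1ccc(O)cc1`: > 30000 nM

Both values are limits of the assay, not numbers. Compound 2 therefore stands only at the limit of > 30000 nM in this assay, at which 2 of the 2 values shown sit. Compound 3 `CCCCCCCCCCCCCCCCOc1cccc(O)c1C(=O)/C=C/c1ccc(O)cc1` differs from it by ethyl in place of hydrogen on a saturated chain carbon, ten or more bonds along the chain from an oxygen on an aromatic ring. Within the data shown here, the one measured step of this kind, a step that the two limits leave unreadable from compound 1 to compound 2, placed butyl in place of hydrogen at the same kind of place, and its size cannot be read. With no measured size to go on, no step beyond the scatter is expected in this assay, and the expected change is a step that the limit leaves unreadable from compound 2 to compound 3. Another limit is likely. The estimate for compound 3 is 35000 nM, with an expected range of 15000 nM to 80000 nM.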

Compound 3, half-maximal inhibitory concentration: > 30000 nM
Compound 3 was reported as a limit; the forecaster's own chance of this, stated with the estimate: 85%; the middle value lies beyond the limit too.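

No step can be read between compound 1, compound 2 and compound 3, since each value is a limit and not a number, and all three sit together: the limit of > 30000 nM in this assay, at which 3 of the 3 values shown sit.

As far as these compounds go, whether the chain length on the shared core changes the result in this assay at all stays open.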